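Methyl for Methoxy on a Fused Five-Ring Core

The compounds below may be only part of what the source reports. "The series", "measured", "known", "first", "only" and "open" are said of these compounds alone.

Of the compounds shown here, three have so far been measured in a functional assay on LoVo cells (Homo sapiens) for cytotoxicity, read by MTT assay, with a stated time of 72 h; a higher number here means a weaker inhibitor, a lower number a stronger inhibitor. Compound 1 `Cc1ccc2[nH]c(-c3ccc[nH]3)c(C3CC(=O)NC3=O)c2c1` gives 4000 nM. Compound 2 `COc1ccc2[nH]c(-c3ccc[nH]3)cc2c1` gives 26000 nM. Compound 3 `COc1ccc2[nH]c3c(c4c(c5ccnn53)C(=O)NC4=O)c2c1` gives 34000 nM, the highest of the three numbers; compound 2 sits within the scatter of it, while compound 1 lies beyond the scatter with a lower number. Compound 4 `Cc1ccc2[nH]c3c(c4c(c5ccnn53)C(=O)NC4=O)c2c1` has not yet been measured. It differs from compound 3 in one place: methyl in place of methoxy on an aromatic carbon. Among the measured compounds shown here, no pair of measured compounds differs by the same change, so nothing measured shows what this change does. The step of a 1.4-fold lower number from compound 3 to compound 4 (0.13 log units; within the scatter) is expected to be small, if anything toward a lower number, and not clearly beyond the scatter. Compound 4 is expected to give 25000 nM in this assay, between 8000 nM and 80000 nM.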

Compound 4, half-maximal inhibitory concentration: 4000 nM
Estimate against measurement, compound 4: 6.3-fold (0.80 log units) above; the whole stated range lies above it.
By their numbers in this assay, from the lowest: compounds 1 and 4 (each within the scatter of the next); then compounds 2 and 3 (each within the scatter of the next).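

In this assay, among the compounds shown here, methyl in place of methoxy on this aromatic carbon gives an 8.5-fold lower number from compound 3 to compound 4 (0.93 log units; beyond the scatter), so this position responds to the group it carries, a point no earlier pair could show. The change removes an oxygen and a hydrogen-bond acceptor, but this single pair cannot separate those differences. Nothing available accounts for the size of the step. On these data alone, whether chlorine, an ethyl chain or an amine on this carbon would give a number nearer that of compound 4 or compound 3 stays open. So does whether the same change would act alike on another core.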